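Replacing the diethylamino group on compound 3 with a branched amine

A few compounds are considered here, and "the series" means these few. Any claim that something is new, unique, unknown or untested is made for them only; others in the source may bear on it.

Compound 3 `CCN(CC)c1nc(C)nc2c1nnn2-c1ccc(C(C)C)cc1Br` gives the lowest number of the three compounds measured in an in vitro assay on 293-EBNA cells for binding affinity to corticotropin-releasing factor receptor 1 (Homo sapiens) (on this read-out lower numbers stand for stronger inhibition and higher numbers for weaker inhibition), namely 25.3 nM. Compound 2 `CCC(COC)Nc1nc(C)nc2c1nnn2-c1c(C)cc(C)cc1C` comes nearest with 59.4 nM, and compound 1 `COCCNc1nc(C)nc2c1nnn2-c1c(C)cc(C)cc1C` lies furthest away with 1200 nM. Compound 4 `CCCC(CN(C)C)Nc1nc(C)nc2c1nnn2-c1ccc(C(C)C)cc1Br` differs from compound 3 in one place: a group of 9 heavy atoms (7 carbon, 2 nitrogen; no ring) in place of a group of 5 heavy atoms (4 carbon, 1 nitrogen; no ring), on an aromatic carbon.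

Going by the values given here, only one measured step bears on this change. The step of a 20-fold lower number from compound 1 to compound 2 (1.31 log units; beyond the scatter) shows that a secondary amine with a branched chain on the saturated chain carbon bound to the nitrogen gave a much lower number than the unbranched one. Compound 4 carries such a branched secondary amine in the place where compound 3 carries diethylamino, and compound 2 and compound 3, with different amines and different aryl groups, give numbers that lie only modestly apart. A step of a 1.7-fold lower number from compound 3 to compound 4 (0.23 log units; within the scatter) is therefore expected for compound 4, with the branched amine most likely holding or improving the number. Compound 4 is estimated at 15 nM, within a range from 4 nM to 60 nM.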

Compound 4, inhibition constant: 38.7 nM
For compound 4 the middle estimate is 2.6-fold (0.41 log units) below the measured one; the measured number falls inside the stated range.
By their numbers in this assay, from the lowest: compounds 3, 4 and 2 (each within the scatter of the next, the first and the last beyond it); then compound 1.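

In this assay, exchanging diethylamino for the larger open-chain amine gives a 1.5-fold higher number from compound 3 to compound 4 (0.18 log units; within the scatter), so the aromatic carbon next to the ring nitrogen accepts this group of 9 heavy atoms, with its added hydrogen-bond donor and second nitrogen, without a change that can be read. The earlier step, a 20-fold lower number from compound 1 to compound 2 (1.31 log units; beyond the scatter), came from compounds with a different aryl group, and with the aryl group of compound 3 the branched secondary amine shows no gain over diethylamino. Nothing given here accounts for the two amines reading alike.

From the compounds shown here alone, what remains open is how much of this result belongs to the dimethylamino end of the chain and how much to its propyl branch, which a hydroxyl in place of the dimethylamino group would help to separate. Also open, going by these compounds, is how a cyclic amine such as morpholine would read at this position.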